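Methoxy in Place of Methyl on the Amide Aryl Group

The source may report more compounds than this note shows. Statements on the series, on what has been measured and on what is new or still open speak of the compounds shown alone.

Measured compounds:
compound 1, `COc1ccc2c(=O)c(/C=C/C(=O)Nc3cccc(C)c3)coc2c1`: > 100000 nM
compound 2, `COc1ccc2c(=O)c(/C=C/C(=O)Nc3ccccc3)coc2c1`: > 100000 nM
compound 3, `COc1cccc(NC(=O)/C=C/c2coc3cc(OC)ccc3c2=O)c1`: 19200 nM

In a functional assay on HeLa cells (Homo sapiens) for inhibition, read by MTT assay, with a stated time of 48 h (a higher number here means a weaker inhibitor, a lower number a stronger inhibitor), compound 1 gives only a limit, > 100000 nM. Compound 2 likewise reaches only a limit, > 100000 nM. Within the data shown here, compound 3 is the one compound with a firm number, 19200 nM. The step of an at least 5.2-fold lower number from compound 1 to compound 3 (0.71 log units; beyond the scatter) and the step of an at least 5.2-fold lower number from compound 2 to compound 3 (0.71 log units; beyond the scatter) both show a methoxy on the aromatic carbon bringing the number down, while the step that the two limits leave unreadable from compound 1 to compound 2 cannot be sized, given (the limit of > 100000 nM in this assay, at which 2 of the 3 values shown sit).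

Compound 4, `COc1ccc2c(=O)c(/C=C/C(=O)Nc3ccccc3OC)coc2c1`, differs from compound 1 by 2-methoxyphenyl in place of 3-methylphenyl on an amide-type nitrogen. Among the measured compounds shown here, the two readable steps bear on it, yet the methoxy of compound 4 enters as 2-methoxyphenyl, a placement no measured compound carries, so their size transfers only loosely. Compound 4 is therefore expected to show an at least 1.6-fold lower number from compound 1 to compound 4 (0.22 log units; that floor lies within the scatter), a lower number. The estimate for compound 4 is 60000 nM, within 15000 nM to 200000 nM.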

Compound 4, half-maximal inhibitory concentration: > 100000 nM
Compound 4 ended at the assay's limit (the forecaster's own chance of this, stated with the estimate: 55%); middle value at least 1.6-fold (0.22 log units) away from the limit.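

In this assay, changing the methoxyphenyl group on the amide-type nitrogen gives an at least 5.2-fold higher number from compound 3 to compound 4 (0.71 log units; beyond the scatter). A methoxy on the amide aryl group therefore does not by itself bring the number down, and among the compounds shown only the 3-methoxyphenyl compound, compound 3, gives a firm number. The steps from compound 1 and from compound 2 to compound 4 cannot be read: the limit of > 100000 nM in this assay, at which 3 of the 4 values shown sit.

From the compounds shown here alone, how far compound 4 lies past its limit stays open. So does whether an ethoxy or an amine in place of the methoxy of compound 3 would give a firm number.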